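Trading a trifluoromethyl-methoxyphenyl for a dimethylphenyl

The compounds below may be only part of what the source reports. "The series", "measured", "known", "first", "only" and "open" are said of these compounds alone.

Compound 1 `COc1cc(-c2c(C)nn(-c3nc(-c4ccc(Cl)c(Cl)c4)c(SC(C)C)s3)c2C(=O)O)cc(C(F)(F)F)c1` is the reference point of this small set. In a functional assay on BJAB cells (Homo sapiens) for antiproliferative activity, with a stated time of 4 days (a higher number here means that more compound is needed for the effect, a lower number that less compound is needed), compound 1 gives 1380 nM, the lower of the two numbers reported. Compound 2 `CCSc1sc(-n2nc(C)c(Cc3ccccc3[N+](=O)[O-])c2C(=O)O)nc1-c1ccc(Cl)c(Cl)c1` gives 59000 nM in this assay, a gap from compound 1 that lies well beyond the usual scatter. Compound 3 `Cc1c(-c2cc(Cl)cc(Cl)c2)c(C(=O)O)nn1-c1nc(-c2cnn(C)c2)c(SC(C)C)s1` is reported in this assay as "not active" (no number reported), with no number attached. Compound 1 is therefore the more potent of the two compounds that carry a number, while compound 3 offers no numerical comparison.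

The next compound, compound 4 `Cc1cc(C)cc(-c2c(C)nn(-c3nc(-c4ccc(Cl)c(Cl)c4)c(SC(C)C)s3)c2C(=O)O)c1`, differs from compound 1 in one place: 3,5-dimethylphenyl in place of 3-methoxy-5-(trifluoromethyl)phenyl on an aromatic carbon. Among the compounds with values here, no measured pair in this set isolates this change, so its effect is not known from the data. The shift in this assay from compound 1 to compound 4 is expected to be modest, a 1.8-fold higher number from compound 1 to compound 4 (0.26 log units; within the scatter), with the direction uncertain and a loss of potency somewhat more likely than a gain. On that basis compound 4 is estimated at 2500 nM in this assay, within a range of 600 nM to 12000 nM.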

Compound 4, half-maximal effective concentration: 2700 nM
Compound 4: middle estimate off by 1.1-fold (0.03 log units), on the low side; the measured number falls inside the stated range.
By their numbers in this assay, from the lowest: compounds 1 and 4 (each within the scatter of the next); then compound 2.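

Placing 3,5-dimethylphenyl in place of 3-methoxy-5-(trifluoromethyl)phenyl on this aromatic carbon gives a 2.0-fold higher number from compound 1 to compound 4 (0.29 log units; within the scatter) in this assay. Within the data shown here, this is the first step in the set that isolates a single change at this position, and it shows that the oxygen and fluorine atoms of the group that leaves are not required to keep the number within the scatter of that of compound 1. The data offer no independent measurement that could account for this result.

Still open, going by these compounds, is whether an amine or a nitrile in place of the methyl groups of compound 4 would keep the number in this range. Equally open, on these data alone, is how a longer chain, such as propyl, would fare on the same phenyl ring.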